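The source may hold more compounds than are shown below. What is called first, only, known or untested is meant among the compounds shown, and "the series" means these compounds.

Compound 1 `C=C1C2=C(C(=O)N1OC)[C@H](OC(=O)CSc1nc3ccccc3s1)[C@@](C)(O)[C@H](CCCCC)O2`: 4700 nM
Compound 2 `C=C1C2=C(C(=O)N1OC)[C@H](OC(=O)CSc1nc3ccccc3o1)[C@@](C)(O)[C@H](CCCCC)O2`: 4900 nM
Compound 3 `C=C1C2=C(C(=O)N1OC)[C@@H](F)[C@@](C)(O)[C@H](CCCCC)O2`: 31000 nM

In a functional assay on HCT-116 cells (Homo sapiens) for cytotoxicity, read by MTT assay, with a stated time of 72 h (on this read-out higher numbers stand for weaker inhibition and lower numbers for stronger inhibition), compound 2 gives the second highest of the three numbers; compound 1 sits within the scatter of it, while compound 3 lies a good way higher. Compound 4 `C=C1C2=C(C(=O)N1OC)[C@H](OC(=O)CCl)[C@@](C)(O)[C@H](CCCCC)O2` has not yet been measured. It differs from compound 2 by chloro in place of (1,3-benzoxazol-2-yl)sulfanyl on a saturated chain carbon bound to a carbonyl carbon. For the measured compounds named here, only one measured step is at hand, a 1.0-fold higher number from compound 1 to compound 2 (0.02 log units; within the scatter), a swap of one bicyclic ring for another that leaves the number unchanged; no measured step removes the bicyclic group entirely. Compound 3, which carries no ester at all, gives 31000 nM, a much higher number than compound 2. Compound 4 keeps the ester but loses the bicyclic group, so a moderately higher number is expected, a 1.8-fold higher number from compound 2 to compound 4 (0.26 log units; within the scatter). Compound 4 is therefore estimated at 9000 nM, in a range from 3500 nM to 25000 nM.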

Compound 4, half-maximal inhibitory concentration: 2400 nM
For compound 4 the middle estimate is 3.8-fold (0.57 log units) above the measured one; the whole stated range lies above it.
By their numbers in this assay, from the lowest: compounds 4, 1 and 2 (each within the scatter of the next, the first and the last beyond it); then compound 3.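

In this assay, the bicyclic group on the saturated chain carbon bound to a carbonyl carbon proves unnecessary for activity, since a single chlorine in place of (1,3-benzoxazol-2-yl)sulfanyl gives a 2.0-fold lower number from compound 2 to compound 4 (0.31 log units; beyond the scatter) and the number does not rise. The same kind of replacement of (1,3-benzothiazol-2-yl)sulfanyl gives a 2.0-fold lower number from compound 1 to compound 4 (0.29 log units; within the scatter), so only the first of these two steps is a real gain. Nothing measured here accounts for either step.

Going by these compounds, whether the chlorine itself matters stays open: a plain acetate ester, with only hydrogens on this carbon, would test that. An amine or a methoxy group on the same carbon is equally untested here.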